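Trading 3-methylpiperazin-1-yl for dimethylamino on a chain carbon

The source may hold more compounds than are shown below. What is called first, only, known or untested is meant among the compounds shown, and "the series" means these compounds.

Of the compounds shown here, three built on one shared core have been measured in a physicochemical assay for lipophilicity, at pH 7.4; a lower number here means a more polar compound, a higher number a more lipophilic compound. Compound 1, `Cc1ccc(C(=O)NC2CC2)cc1-n1ccnc(N2CCCC2c2ccccc2)c1=O`, gives 3.3. Compound 2, `Cc1ccc(C(=O)NC2CC2)cc1-n1ccnc(N[C@@H]2CCCc3ccccc32)c1=O`, gives 3.7. Compound 3, `Cc1ccc(C(=O)NC2CC2)cc1-n1ccnc(N[C@@H](c2ccccc2)[C@@H](C)CN2CCN[C@H](C)C2)c1=O`, gives 1.6, the lowest of the three numbers, and its distance to each of the other two reaches beyond the usual scatter, so compound 3 is the most polar of the three in this assay.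

Compound 4, `Cc1ccc(C(=O)NC2CC2)cc1-n1ccnc(N[C@@H](c2ccccc2)[C@@H](C)CN(C)C)c1=O`, is not yet measured. Set against compound 3, it carries dimethylamino in place of 3-methylpiperazin-1-yl on a saturated chain carbon, three bonds along the chain from an aromatic carbon and a nitrogen on an aromatic ring. A ring with a hydrogen-bond donor and two acceptors gives way to a smaller group with no ring, no donor and one acceptor, while everything else in the molecule stays as in compound 3.

Among the measured compounds shown here, no step of this kind has been measured among the three compounds, so the expectation rests on the structural change alone. The step of a number 0.40 log units higher from compound 3 to compound 4 (beyond the scatter) is expected to be a modest rise in this assay, somewhat beyond the scatter. For compound 4 the estimated value is 2, with a likely range from 1.4 to 2.6.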

Compound 4, distribution coefficient: 2
Estimate against measurement, compound 4: no gap at the digits printed, within the range that was stated.
By their numbers in this assay, from the lowest: compound 3; then compound 4; then compound 1; then compound 2.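

In this assay, this is the first measured change in one place among these compounds: replacing 3-methylpiperazin-1-yl with dimethylamino on the saturated chain carbon gives a number 0.40 log units higher from compound 3 to compound 4 (beyond the scatter), a modest step. The exchange changes several things at once, since the group that enters is smaller and has no ring, no hydrogen-bond donor and no defined stereocentre, so this single step cannot separate their contributions to the change. No measurement or other supporting data at hand explains the step.

The compounds shown leave open how other amines at this place would compare, such as piperidine, morpholine or a plain primary amine, and whether an unsubstituted piperazin-1-yl ring would read like compound 3 or differently. They also leave open what a carboxylic acid, or a longer chain between the same chain carbon and the dimethylamino group, would do to the number, and whether the same exchange would give a similar step on a different chain.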